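From compound 3 to compound 4: benzyl for tert-butyl

The compounds below may be only part of what the source reports. "The series", "measured", "known", "first", "only" and "open" are said of these compounds alone.

Compound 1 `CCCCCCCOc1ccc(CCC(CO)(CO)NC(=O)CCCCC)c2ccccc12` gives 21900 nM
Compound 2 `CCCCCCCOc1ccc(CCC(CO)(CO)NC(=O)OCCCC)c2ccccc12` gives 22400 nM
Compound 3 `CCCCCCCOc1ccc(CCC(CO)(CO)NC(=O)OC(C)(C)C)c2ccccc12` gives 21400 nM

These values come from a functional assay on HT-29 cells (Homo sapiens) for antiproliferative activity, read by sulforhodamine B assay, with a stated time of 72 h (a lower number here means a stronger inhibitor, a higher number a weaker inhibitor), and cannot be told apart. Compound 3 stands level with the other two, as a 1.0-fold lower number from compound 1 to compound 3 (0.01 log units; within the scatter) and a 1.0-fold lower number from compound 2 to compound 3 (0.02 log units; within the scatter) both show. The next compound to be tested is compound 4 `CCCCCCCOc1ccc(CCC(CO)(CO)NC(=O)OCc2ccccc2)c2ccccc12` which has benzyl in place of tert-butyl on an oxygen next to a carbonyl group and keeps the rest of compound 3 unchanged.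

The closest evidence is the exchange on that same oxygen, a 1.0-fold lower number from compound 2 to compound 3 (0.02 log units; within the scatter) and the wider change at this site, a 1.0-fold higher number from compound 1 to compound 2 (0.01 log units; within the scatter) adds to it. Among the measured compounds shown here, neither moved the number beyond the scatter, although no measured compound carries a ring at this place, so the data leave that feature untested. The expected change is a 1.1-fold lower number from compound 3 to compound 4 (0.05 log units; within the scatter) and no step beyond the scatter is anticipated. In this assay compound 4 is estimated at 19000 nM with 10000 nM to 33000 nM as its expected range.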

Compound 4, half-maximal inhibitory concentration: 60500 nM
Compound 4: middle estimate off by 3.2-fold (0.50 log units), on the low side; measured number outside the range, above it.
By their numbers in this assay, from the lowest: compounds 3, 1 and 2 (each within the scatter of the next); then compound 4.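

In this assay, among the compounds shown here, benzyl on the oxygen next to a carbonyl group gives the first change at this site that goes beyond the scatter, with a 2.8-fold higher number from compound 3 to compound 4 (0.45 log units; beyond the scatter) against a tert-butyl, butyl or pentyl series that had stayed level. For the compounds shown here, the step is much the same from the other two compounds, with a 2.7-fold higher number from compound 2 to compound 4 (0.43 log units; beyond the scatter) and a 2.8-fold higher number from compound 1 to compound 4 (0.44 log units; beyond the scatter) both showing that this site is not indifferent to what it carries, and that compound 4, the only compound here with an aromatic ring at this place, is the weakest of the four. No evidence on the cause of this loss is available.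

The compounds shown leave open whether the ring or the added carbons go with this step, as neither cyclohexylmethyl nor a longer chain on this oxygen appears among them. Also open, as far as these compounds go, is how an amine or a carboxylic acid on the benzyl ring would read in this assay.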